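Chloro in Place of Methoxy on the Benzyl of Compound 3

A few compounds are considered here, and "the series" means these few. Any claim that something is new, unique, unknown or untested is made for them only; others in the source may bear on it.

Compound 1, `COc1ccc(CN2CCc3nc(-c4ccccn4)nc(N4CCC(C(N)=O)CC4)c3C2)cc1`: 86.6%
Compound 2, `COc1ccc(CN2CCc3nc(-c4ccccn4)nc(N4CCN(CC(N)=O)CC4)c3C2)cc1`: 35.9%
Compound 3, `CCN(C(C)=O)C1CCN(c2nc(-c3ccccn3)nc3c2CN(Cc2ccc(OC)cc2)CC3)C1`: 36.9%

Three compounds share one core and were measured in an assay on FRT cells with Cystic fibrosis transmembrane conductance regulator variant F508del (Homo sapiens) as the target, read by fluorescence, with a stated time of 25 min; a lower number here means a smaller maximal response, a higher number a larger maximal response. Compound 3 stands second highest of the three; its nearest neighbour is compound 2, which differs from it by a number 1 percentage points higher from compound 2 to compound 3 (within the scatter), while compound 1 stands far above it, as a number 49.7 percentage points lower from compound 1 to compound 3 (beyond the scatter) shows. The other measured step, a number 50.7 percentage points lower from compound 1 to compound 2 (beyond the scatter), is of the same large size, and all three steps concern the group on the aromatic carbon of the core, not the benzyl.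

Compound 4, `CCN(C(C)=O)C1CCN(c2nc(-c3ccccn3)nc3c2CN(Cc2ccc(Cl)cc2)CC3)C1`, differs from compound 3 in one place: chloro in place of methoxy on an aromatic carbon. Read one bond further out, it is 4-methoxybenzyl turning into 4-chlorobenzyl. Within the data shown here, none of the measured steps touches this part of the molecule, so no measured step bears directly on the change; the benzyl group is the same in compounds 1, 2 and 3. With nothing pointing either way, the step from compound 3 to compound 4 in this assay is expected to be a number 0.1 percentage points higher from compound 3 to compound 4 (within the scatter), that is, none beyond the scatter. Compound 4 is therefore estimated at 37%, within a range from 22% to 55%.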

Compound 4, largest response reached (Emax), in percent of the reference or control that the assay uses in the Cystic fibrosis transmembrane conductance regulator assay: "not active" (no number reported)
Compound 4: no number reported, and the estimate cannot be compared.
By their numbers in the Cystic fibrosis transmembrane conductance regulator assay, from the lowest: compounds 2 and 3 (each within the scatter of the next); then compound 1.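

Among these compounds, in the Cystic fibrosis transmembrane conductance regulator assay compound 4 is reported as not active, with no number, so no step from compound 3 to compound 4 can be read there. In a physicochemical assay for solubility, read by HPLC, with a stated time of 24 h, at pH 7.4, tested at 250 uM (a lower number here means a less soluble compound, a higher number a more soluble compound), compound 3 stands at 218000 nM and compound 4 at 223000 nM with a 1.0-fold higher number from compound 3 to compound 4 (0.01 log units; within the scatter) between them. No evidence at hand bears on this result.

The compounds shown leave open how chloro in place of methoxy on the benzyl would read in numbers for the maximal response.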